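Swapping Chloro for Cyano on Two Urea Scaffolds

This account rests on a few compounds, and the source may have more. Where it says the series, first, only, none or still open, it means among the compounds named here.

Compound 1 `COc1ccc(CN(C(=O)Nc2ccc(Cl)cc2)n2cnnc2)cc1OC` and compound 2 `COc1ccc(CN(C(=O)Nc2ccc(C#N)cc2)n2cnnc2)cc1OC` share one core, while compound 3 `Cc1ccsc1CN(C(=O)Nc1cccc(Cl)c1)n1cnnc1` and the still unmeasured compound 4 `Cc1ccsc1CN(C(=O)Nc1cccc(C#N)c1)n1cnnc1` share another; how the two cores differ is not broken down here. In a functional assay on MDA-MB-231 cells (Homo sapiens) for cytotoxicity, read by MTT assay, with a stated time of 48 h (on this read-out lower numbers stand for stronger inhibition and higher numbers for weaker inhibition), compound 1 gives only a limit of the assay, > 50000 nM. Compound 2 likewise gives only a limit, > 50000 nM. Compound 3 gives a number, 40300 nM. The change cyano in place of chloro on an aromatic carbon made a step that the two limits leave unreadable from compound 1 to compound 2 because of the limit of > 50000 nM in this assay, at which 2 of the 3 values shown sit. Compound 4 carries the same kind of change, (cyano in place of chloro on an aromatic carbon); the surroundings differ, the group sitting para to a large group in compound 1 but meta to a large group in compound 3. With no readable step to rest on, the expected step is a 1.1-fold higher number from compound 3 to compound 4 (0.05 log units; within the scatter). Compound 4 is expected to give about 45000 nM, most likely between 15000 nM and 150000 nM.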

Compound 4, half-maximal inhibitory concentration: > 50000 nM
Compound 4 was reported as a limit; the forecaster's own chance of this, stated with the estimate: 40%; at least 1.1-fold (0.04 log units) between middle value and limit.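

In this assay compound 4 gives > 50000 nM, which is a limit of the assay and not a number. Cyano in place of chloro on this core makes an at least 1.2-fold higher number from compound 3 to compound 4 (0.09 log units; that floor lies within the scatter), so the change brings no stronger inhibition here, while the true size of the step stays unknown. The step from compound 1 to compound 2 cannot be read, so the two cores cannot be compared and nothing shows how well the change carries from one to the other, because so many values sit at the same limit: the limit of > 50000 nM in this assay, at which 3 of the 4 values shown sit.

As far as these compounds go, it remains open whether a different group in place of chloro on the 3-chlorophenyl, such as an amine or a carboxylic acid, would give a lower number. A readable comparison between the cores would need values that fall inside the range of the assay.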